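The source may hold more compounds than are shown below. What is called first, only, known or untested is meant among the compounds shown, and "the series" means these compounds.

Of the compounds shown here, three of one dienone series have been tested so far. Compound 1 `COc1ccc(/C=C/C=C/C(=O)c2ccccc2O)cc1OC` carries two methoxy groups on its distal aromatic ring, and in an in vitro assay on cells for inhibition of Amine oxidase [flavin-containing] A (Homo sapiens), read by Amplex Red, with a stated time of 15 min, tested at 100 uM (a higher number here means more inhibition at the concentration tested (going by the name of the read-out), a lower number less inhibition), compound 1 gives 40%. Compound 2 `O=C(/C=C/C=C/c1ccccc1)c1cc(Cl)ccc1O` instead bears chlorine on the phenolic ring and no substituent on the distal ring; in this assay compound 2 was reported only as "not active" (no number reported), so no single number stands for it. Compound 3 `COc1ccc(/C=C/C=C/C(=O)c2cc(Cl)ccc2O)cc1`, with one methoxy group on the distal ring and the same chlorinated phenol, was likewise reported in this assay as "not active" (no number reported). Compound 2 thus stands with one other compound for which no number was obtained, while only compound 1 has a measured value.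

Compound 4 `O=C(/C=C/C=C/c1ccc([N+](=O)[O-])cc1)c1cc(Cl)ccc1O` is now to be measured. It differs from compound 2 by nitro in place of hydrogen on an aromatic carbon. Going by the values given here, no step between measured compounds is available to size this change, so the direction can only be guessed. Since compound 2 and compound 3 both gave no reportable number, only a small shift, if any beyond the scatter, is expected. For compound 4 in this assay an inhibition of about 12% is estimated, within a range from 0% to 35%.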

Compound 4, a percentage reported as inhibition, at one concentration (the size of the read-out at that concentration, not a potency): "not active" (no number reported)
The entry for compound 4 holds no number, so the estimate cannot be set against anything.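

In this assay, going by these compounds alone, compound 2 gives "not active" (no number reported) and compound 4 gives "not active" (no number reported) so no step between compound 2 and compound 4 can be read. The compounds shown leave open what effect, if any, nitro in place of hydrogen has on inhibition. No evidence at hand bears on this result.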